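Methoxy for Fluoro on the Fused Ring of Compound 2

The source may report more compounds than this note shows. Statements on the series, on what has been measured and on what is new or still open speak of the compounds shown alone.

Compound 2 `COc1cc(-c2ccc(C)n2-c2ccc(-c3nc4ccc(F)cc4s3)cc2)cc(OC)c1OC` shows the lowest of three numbers in a functional assay on MDA-MB-231 cells (Homo sapiens) for cytotoxicity, read by sulforhodamine B assay, with a stated time of 48 h (a higher number here means a weaker inhibitor of growth, a lower number a stronger inhibitor of growth), at 3000 nM, though compound 1 `COc1cc(-c2ccc(C)n2-c2ccc(-c3nc4ccccc4s3)cc2)cc(OC)c1OC` at 3450 nM and compound 3 `COc1ccc(-c2ccc(C)n2-c2ccc(-c3nc4ccc(OC)cc4s3)cc2)cc1` at 4120 nM both lie within the scatter of it. For the measured compounds named here, the only single step among them, a 1.2-fold lower number from compound 1 to compound 2 (0.06 log units; within the scatter), was within the scatter. Compound 4 `COc1ccc2nc(-c3ccc(-n4c(C)ccc4-c4cc(OC)c(OC)c(OC)c4)cc3)sc2c1` differs from compound 2 by methoxy in place of fluoro on an aromatic carbon. Going by the values given here, no measured step swaps these two groups, and compound 3 also bears a methoxy but differs from compound 2 in more than one place, so its value cannot be read as a step. Given a 1.2-fold lower number from compound 1 to compound 2 (0.06 log units; within the scatter), compound 4 is expected to show a 1.1-fold higher number from compound 2 to compound 4 (0.04 log units; within the scatter), nothing beyond the scatter. Compound 4 is therefore estimated at 3300 nM, between 1500 nM and 7500 nM.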

Compound 4, concentration for 50% growth inhibition: 1760 nM
The estimate for compound 4 lay 1.9-fold (0.27 log units) above the measured number, within the range that was stated.
By their numbers in this assay, from the lowest: compounds 4, 2, 1 and 3 (each within the scatter of the next, the first and the last beyond it).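

In this assay the change from 6-fluoro-1,3-benzothiazol-2-yl to 6-methoxy-1,3-benzothiazol-2-yl gives a 1.7-fold lower number from compound 2 to compound 4 (0.23 log units; within the scatter) and methoxy in place of hydrogen gives a 2.0-fold lower number from compound 1 to compound 4 (0.29 log units; within the scatter) on the same carbon, so hydrogen, fluoro and methoxy have now all stood here with no step beyond the scatter. Methoxy brings a hydrogen-bond acceptor by the count, and even so the number stays within the scatter. Nothing available explains these numbers.

On these data alone, whether an amine or a carboxylic acid on this carbon would give a step beyond the scatter remains open.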